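The source may report more compounds than this note shows. Statements on the series, on what has been measured and on what is new or still open speak of the compounds shown alone.

Measured in a functional assay, with a stated time of 30 min (a lower number here means a stronger inhibitor, a higher number a weaker inhibitor), so far:
- compound 1, `CCCCc1oc2ccc(/N=C/c3ccc(O)cc3)cc2c1C(=O)c1ccc(OC)cc1`: 22.8 ug/mL
- compound 2, `CCCCc1oc2ccc(/N=C/c3ccc(F)cc3)cc2c1C(=O)c1ccc(OC)cc1`: 100 ug/mL
- compound 3, `CCCCc1oc2ccc(/N=C/c3ccccc3)cc2c1C(=O)c1ccc(OC)cc1`: 34.2 ug/mL

Compound 3 sits second highest of the three numbers in this assay, with compound 1 nearest (a 1.5-fold higher number from compound 1 to compound 3 (0.18 log units; within the scatter)) and compound 2 furthest (a 2.9-fold lower number from compound 2 to compound 3 (0.47 log units; beyond the scatter)).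

Compound 4, `CCCCc1oc2ccc(/N=C/c3ccc([N+](=O)[O-])cc3)cc2c1C(=O)c1ccc(OC)cc1`, differs from compound 3 by nitro in place of hydrogen on an aromatic carbon.

The three measured steps all sit at this same aromatic carbon. Replacing hydroxy by hydrogen moved little (a 1.5-fold higher number from compound 1 to compound 3 (0.18 log units; within the scatter)); replacing hydroxy by fluoro raised the number modestly (a 4.4-fold higher number from compound 1 to compound 2 (0.64 log units; beyond the scatter)); and removing fluoro brought it back down (a 2.9-fold lower number from compound 2 to compound 3 (0.47 log units; beyond the scatter)). Nitro at this place has no measured precedent in the series, so the direction is uncertain; the substituents tried so far span from no change to a modest rise, and a modest rise is taken as the more likely outcome, with a wide range.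

For compound 4 the expected step in this assay is a 1.6-fold higher number from compound 3 to compound 4 (0.21 log units; within the scatter), giving an estimated 55 ug/mL (range 20 ug/mL to 150 ug/mL).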

Compound 4, half-maximal inhibitory concentration: 53.1 ug/mL
Beside the measured number, compound 4's estimate is 1.0-fold (0.02 log units) above it; low and high end bracket the measured number.
By their numbers in this assay, from the lowest: compounds 1, 3, 4 and 2 (each within the scatter of the next, the first and the last beyond it).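

In this assay nitro at this aromatic carbon, para to a large group, stays within the scatter of hydrogen (a 1.6-fold higher number from compound 3 to compound 4 (0.19 log units; within the scatter)) and of fluoro (a 1.9-fold lower number from compound 2 to compound 4 (0.27 log units; within the scatter)). Only against hydroxy does the step pass beyond the scatter (a 2.3-fold higher number from compound 1 to compound 4 (0.37 log units; beyond the scatter)), and it remains modest. Among these compounds, a group with more heavy atoms than hydrogen or fluoro is therefore accepted here without a clear separation from either, while the gap between compound 2 and compound 3 is the only other step at this carbon beyond the scatter besides those from compound 1.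

As far as these compounds go, an amine or a carboxylic acid at this carbon remains open, as does whether the same order holds with a longer chain in place of the butyl group. Nothing available bears on what lies behind these differences.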